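From benzyl ether to 2-chlorophenyl ether on a shared core

The source may report more compounds than this note shows. Statements on the series, on what has been measured and on what is new or still open speak of the compounds shown alone.

Measured compounds:
compound 1 `O=C1NC(=O)C(Cc2ccc(Oc3ccc(C(F)(F)F)cc3Cl)cc2)S1` gives 78 nM in a functional assay for agonist activity at Free fatty acid receptor 1 (Homo sapiens), read by FLIPR, in the presence of a further agent that is not named here; on this read-out lower numbers stand for an effect already at smaller amounts and higher numbers for an effect only at larger amounts of compound
compound 2 `Cc1ccccc1Oc1ccc(CC2SC(=O)NC2=O)cc1` gives 124 nM in this assay
compound 3 `O=C1NC(=O)C(Cc2ccc(OCc3ccccc3)cc2)S1` gives 6180 nM in this assay

Among these three, compound 3 stands at the highest number in this assay: its nearest neighbour is compound 2, whose number is lower by a 50-fold higher number from compound 2 to compound 3 (1.70 log units; beyond the scatter) read in reverse, and the gap to compound 1 is wider still, both beyond the scatter. Compound 4 `O=C1NC(=O)C(Cc2ccc(Oc3ccccc3Cl)cc2)S1` is not yet measured. It differs from compound 3 in one place: 2-chlorophenyl in place of benzyl on an oxygen on an aromatic ring.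

Within the data shown here, one measured step bears on this change. Going from compound 2 to compound 3 replaced 2-methylphenyl by benzyl on the same oxygen, with a 50-fold higher number from compound 2 to compound 3 (1.70 log units; beyond the scatter). The step to compound 4 runs the other way, putting an aryl group with a small substituent back onto that oxygen, and compound 1, which also carries a chlorine-bearing phenyl on the oxygen, shows a low number. Compound 4 is therefore expected to show a large step downward, a 48-fold lower number from compound 3 to compound 4 (1.68 log units; beyond the scatter), in this assay. The estimate for compound 4 is 130 nM, with a range from 40 nM to 400 nM.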

Compound 4, half-maximal effective concentration: 1190 nM
Beside the measured number, compound 4's estimate is 9.2-fold (0.96 log units) below it; the measured number lies above the stated range.
By their numbers in this assay, from the lowest: compounds 1 and 2 (each within the scatter of the next); then compound 4; then compound 3.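

In this assay, 2-chlorophenyl on the oxygen in place of benzyl gives a 5.2-fold lower number from compound 3 to compound 4 (0.72 log units; beyond the scatter), so an aryl group here recovers only part of the ground lost with benzyl. The small substituent on that aryl ring also matters, which compound 2 and compound 3 alone could not show: chloro in place of methyl on an aromatic carbon gives a 9.6-fold higher number from compound 2 to compound 4 (0.98 log units; beyond the scatter) in this comparison. Hydrogen in place of trifluoromethyl gives a 15-fold higher number from compound 1 to compound 4 (1.18 log units; beyond the scatter), so the low number of compound 1 does not carry over to a chlorine-bearing phenyl lacking trifluoromethyl.

No measurement shown explains why these changes move the number as they do. As far as these compounds go, whether fluoro or methoxy in place of chloro on this ring would match the methyl of compound 2 remains open.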